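The compounds below may be only part of what the source reports. "The series", "measured", "known", "first", "only" and "open" are said of these compounds alone.

Measured compounds:
compound 1, `COc1cc(C)cc(-c2c(-c3ccnc(-c4ccc(C(C)=O)cc4)c3)cnn2CC#N)c1`, 73%
compound 2, `Cc1cc(O)cc(-c2nn(CC#N)cc2-c2ccnc(-c3ccc(Oc4ccccc4)cc3)c2)c1`, 86%
compound 3, `COc1cc(C)cc(-c2nn(CC#N)cc2-c2ccnc(-c3ccc(N(C)C)cc3)c2)c1`, 11%

In a functional assay on HCT-116 cells (Homo sapiens) for cytotoxicity, read by sulforhodamine B assay, with a stated time of 48 h, tested at 100 nM (on this read-out lower numbers stand for a stronger effect and higher numbers for a weaker effect at the one concentration tested), compound 3 gives 11%, the lowest of the three numbers. Compound 1 stands nearest to it, and the gap between them lies beyond the scatter; compound 2 stands furthest, again beyond the scatter. Compound 3 is thus the strongest of the three on this read-out.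

Compound 4, `Cc1cc(O)cc(-c2nn(CC#N)cc2-c2ccnc(-c3ccc(N(C)C)cc3)c2)c1`, has not yet been measured in this assay. It differs from compound 3 in one place: hydrogen in place of methyl on an oxygen on an aromatic ring. Among the compounds with values here, no measured pair shows this change on its own, so its effect cannot be read from a step between measured compounds. Compound 2 carries the hydroxy group together with a different group on the other ring and gives 86%, while compound 1 carries the methoxy group with yet another group and gives 73%; neither pair isolates the change. The step from compound 3 to compound 4 is expected to be a modest rise in the number, a number 14 percentage points higher from compound 3 to compound 4 (beyond the scatter), possibly within the scatter. Compound 4 is estimated at 25%, between 8% and 60%.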

Compound 4, a percentage reported as activity, at one concentration (the size of the read-out at that concentration, not a potency): 87%
Compound 4: middle estimate off by 62 percentage points, on the low side; measured number outside the range, above it.
By their numbers in this assay, from the lowest: compound 3; then compound 1; then compounds 2 and 4 (each within the scatter of the next).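

In this assay, methoxy to hydroxy on the 3-methoxy-5-methylphenyl group gives a number 76 percentage points higher from compound 3 to compound 4 (beyond the scatter) with dimethylamino held fixed, so this one small exchange on the oxygen separates the strong effect from a weak one. With the hydroxy group held fixed, dimethylamino in place of phenoxy gives a number 1 percentage points higher from compound 2 to compound 4 (within the scatter) and so shows no difference between these two groups on this read-out. Nothing measured here offers a reason for either result.

From the compounds shown here alone, it stays open whether other groups on this aromatic ring, such as ethoxy, an amine or fluorine, would keep the strong effect seen with methoxy or share the weak one seen with hydroxy. Going by these compounds, it also stays open whether methoxy would bring the same gain with phenoxy on the other ring as it does with dimethylamino.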